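Replacing the nitro group of compound 2 with amino

This account rests on a few compounds, and the source may have more. Where it says the series, first, only, none or still open, it means among the compounds named here.

compound 1 `COc1ccc(Sc2cc(OC)c(OC)c(OC)c2)cc1` gives 16 nM
compound 2 `COc1ccc(Sc2cc(OC)c(OC)c(OC)c2)cc1[N+](=O)[O-]` gives 1000 nM

In a functional assay on MCF7 cells (Homo sapiens) for cytotoxicity, read by sulforhodamine B assay, with a stated time of 96 h (on this read-out lower numbers stand for stronger inhibition and higher numbers for weaker inhibition), compound 2 holds the higher of the two numbers at 1000 nM. Compound 3 `COc1ccc(Sc2cc(OC)c(OC)c(OC)c2)cc1N` carries amino in place of nitro on an aromatic carbon. Among the measured compounds shown here, one measured step bears on this, the large 63-fold higher number from compound 1 to compound 2 (1.80 log units; beyond the scatter), which introduced that nitro group. For the measured compounds named here, no amino compound has been measured, so the size of any recovery is uncertain. A large move to a lower number is expected, a 25-fold lower number from compound 2 to compound 3 (1.40 log units; beyond the scatter). For compound 3 the estimated value is 40 nM, within an expected range of 6 nM to 250 nM.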

Compound 3, half-maximal inhibitory concentration: 8 nM
For compound 3 the middle estimate is 5.0-fold (0.70 log units) above the measured one; the measured number falls inside the stated range.
By their numbers in this assay, from the lowest: compounds 3 and 1 (each within the scatter of the next); then compound 2.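

In this assay, amino in place of nitro gives a 130-fold lower number from compound 2 to compound 3 (2.10 log units; beyond the scatter), so the large loss at this place, ortho to a methoxy group, is not shared by every substituent there. Amino in place of hydrogen gives a 2.0-fold lower number from compound 1 to compound 3 (0.30 log units; within the scatter), so among the three groups shown, only nitro carries a penalty at this place. Nothing available here explains why nitro and amino differ so widely. As far as these compounds go, it remains open whether a hydroxyl, a methylamino or an acetamide group at this place would match amino or follow nitro. From the compounds shown here alone, whether the same pattern holds in other cell lines also remains open.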